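The compounds below may be only part of what the source reports. "The series", "measured", "known", "first", "only" and "open" are said of these compounds alone.

Of the compounds shown here, three have so far been measured in a physicochemical assay for lipophilicity, using the shake flask method, measured as octanol-water partition, at pH 7.4; on this read-out higher numbers stand for higher lipophilicity and lower numbers for lower lipophilicity. Compound 1 `CC(C)n1nc(-c2ccnc3[nH]c(C4CCN(CC(=O)N(C)C)CC4)cc23)ccc1=O` gives 2, the second highest of the three readings. Compound 2 `CC(C)n1cc(-c2ccnc3[nH]c(C4CCN(CC(=O)N5CCCCC5)CC4)cc23)ccc1=O` gives 2.8, a reading above that of compound 1 by more than the usual scatter, while compound 3 `COc1cc(C(=O)N2CCCC2)ccc1-c1ccnc2[nH]c(C3CCNCC3)cc12` gives 0.1, the reading furthest from compound 1 and below it, again beyond the scatter. Compound 4 `CCn1cc(-c2ccnc3[nH]c(C4CCN(CC(=O)N(C)C)CC4)cc23)ccc1=O` has not yet been measured in this assay. It differs from compound 1 in one place: a group of 9 heavy atoms (7 carbon, 1 nitrogen, 1 oxygen; one six-membered aromatic ring with 1 hetero atom) in place of a group of 10 heavy atoms (7 carbon, 2 nitrogen, 1 oxygen; one six-membered aromatic ring with 2 hetero atoms), on an aromatic carbon. Among the measured compounds shown here, no measured pair shows this change alone, so its effect cannot be read from the data. The step of a number 0.20 log units higher from compound 1 to compound 4 (within the scatter) is expected to be small, within the scatter, and upward if anything. Compound 4 is therefore estimated at 2.2, within 1.6 to 2.8.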

Compound 4, distribution coefficient: 1.2
Compound 4: the middle estimate sits 1.00 log units above what was measured, and the stated range ends above it.
By their numbers in this assay, from the lowest: compound 3; then compound 4; then compound 1; then compound 2.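

At this aromatic carbon, opposite the ring nitrogen, exchanging the group with two ring hetero atoms for the one with a single ring hetero atom is not a neutral change in this assay: it gives a number 0.80 log units lower from compound 1 to compound 4 (beyond the scatter), a modest step. Among the compounds shown here, this is the first single-place step available here, and it shows that this position can register such an exchange on this read-out. Nothing shown here bears on the reason for the step.

The compounds shown leave open how much of the step belongs to the ring hetero atom and how much to the rest of the exchanged group. They also leave open whether a group carrying a cyclopropyl or a fluorine at this place would move the number the same way.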